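Capping the hydroxy group of a macrocyclic depsipeptide series

The compounds below may be only part of what the source reports. "The series", "measured", "known", "first", "only" and "open" are said of these compounds alone.

Measured compounds:
compound 1, `C/C=C(\C)[C@H]1OC(=O)[C@@H](C)NC(=O)[C@H]([C@@H](C)CC)NC(=O)CN(C)C(=O)[C@@H](Cc2ccccc2)N(C)C(=O)[C@H](C)NC(=O)[C@@H](CC(C)C)OC(=O)/C(C)=C/C[C@H](O)[C@@H]1C`: 0.0021 nM
compound 2, `C/C=C(\C)[C@@H](O)[C@@H](C)[C@@H]1C/C=C(\C)C(=O)O[C@H](CC(C)C)C(=O)N[C@@H](C)C(=O)N(C)[C@H](Cc2ccccc2)C(=O)N(C)CC(=O)N[C@@H]([C@@H](C)CC)C(=O)N[C@H](C)C(=O)O1`: 0.0014 nM

Of the compounds shown here, two have been measured in a functional assay on A549 cells (Homo sapiens) for cytotoxicity, read by CellTiter-Blue, with a stated time of 72 h; on this read-out higher numbers stand for weaker inhibition and lower numbers for stronger inhibition. Compound 1 gives 0.0021 nM, and compound 2 gives 0.0014 nM. Compound 1 holds the highest of the two numbers, but its gap to compound 2 lies within the scatter, so the two cannot be ordered against each other. Going by the values given here, no pair of measured compounds differs at a single position, so no step size has yet been observed.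

Compound 3, `C/C=C(\C)[C@H]1OC(=O)[C@@H](C)NC(=O)[C@H]([C@@H](C)CC)NC(=O)CN(C)C(=O)[C@@H](Cc2ccccc2)N(C)C(=O)[C@H](C)NC(=O)[C@@H](CC(C)C)OC(=O)/C(C)=C/C[C@H](OCSC)[C@@H]1C`, differs from compound 1 by (methylsulfanyl)methyl in place of hydrogen on an oxygen on a saturated carbon The same change, read one bond further out, is hydroxy to (methylsulfanyl)methoxy. Among the compounds with values here, nothing measured so far shows what replacing the hydrogen of this hydroxy group does, and the two values in hand lie close together. The step of a 1.4-fold higher number from compound 1 to compound 3 (0.15 log units; within the scatter) is expected to be small, most likely within the scatter, with the weaker-inhibition side of the range left somewhat wider for want of any precedent. Compound 3 is estimated at 0.003 nM, within a range from 0.0008 nM to 0.012 nM.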

Compound 3, half-maximal inhibitory concentration: 0.00019 nM
The estimate for compound 3 lay 16-fold (1.20 log units) above the measured number; the measured number lies below the stated range.
By their numbers in this assay, from the lowest: compound 3; then compounds 2 and 1 (each within the scatter of the next).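

In this assay, going by these compounds alone, the first single-place step is large: the change from hydroxy to (methylsulfanyl)methoxy on the saturated carbon gives an 11-fold lower number from compound 1 to compound 3 (1.04 log units; beyond the scatter) and so moves toward stronger inhibition, beyond the scatter. This position is therefore not silent to substitution, and the hydrogen of this hydroxy group is not required for activity at the level seen with compound 1, since its replacement by (methylsulfanyl)methyl gives a lower number rather than a higher one. Nothing at hand explains the size of this step, and no measurement bears on its cause.

The compounds shown leave open whether the sulfur atom matters to the step or whether any cap on this oxygen would do the same: a plain methyl ether, a methoxymethyl ether, an acetyl ester or a longer thioether chain would each separate these readings. They also leave open whether the same (methylsulfanyl)methyl group on the hydroxy group of compound 2 would give a step of similar size, so the result stands for a single pair and a single core.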